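Swapping a neopentyl for a tert-butyl on an inactive core

The compounds below may be only part of what the source reports. "The series", "measured", "known", "first", "only" and "open" are said of these compounds alone.

Measured compounds:
compound 1, `CCOC(=O)Cn1ncc2c(C)ncn2c1=O`, > 48000 nM (a limit)
compound 2, `C=CCn1nc(Br)c2c(Br)nc(CCC)n2c1=O`, > 48000 nM (a limit)
compound 3, `Cc1nc(CC(C)(C)C)n2c(O)nncc12`, > 48000 nM (a limit)

In a functional assay for inhibition, with Homo sapiens as the target (a higher number here means a weaker inhibitor, a lower number a stronger inhibitor), none of the three measured compounds gives a number. Compound 1 reaches only the limit > 48000 nM. Compound 2 likewise sits at the limit > 48000 nM. Compound 3 also stops at the limit > 48000 nM. For the measured compounds named here, compound 3 therefore stands nowhere above or below its neighbours; it shares the limit of > 48000 nM in this assay, at which 3 of the 3 values shown sit, with both of them, and no step between any two measured compounds can be counted.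

Compound 4, `Cc1nc(C(C)(C)C)n2c(O)nncc12`, has not yet been tested in this assay. It differs from compound 3 in one spot: tert-butyl in place of neopentyl on an aromatic carbon. The change shortens the group on an aromatic carbon of the five-membered aromatic ring, the position that lies between two ring nitrogen atoms.

With every measured value resting at the limit, the expected size of the step from compound 3 to compound 4 in this assay is none beyond the scatter, and compound 4 is expected to show a step that the limit leaves unreadable from compound 3 to compound 4. Compound 4 is estimated to land at 60000 nM, in the range 20000 nM to 200000 nM, most likely reported again as a limit.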

Compound 4, half-maximal inhibitory concentration: 31000 nM
Estimate against measurement, compound 4: 1.9-fold (0.29 log units) above; the range from low to high includes it.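

In this assay compound 4 gives a true number, 31000 nM, the first in this set, so the core can yield a readable result when tert-butyl sits on this aromatic carbon between two ring nitrogen atoms. Replacing neopentyl with tert-butyl gives an at least 1.5-fold lower number from compound 3 to compound 4 (0.18 log units; that floor lies within the scatter), and this figure is only a floor, so it does not establish a real gain. The true size of the step stays unknown because the other compounds give no number: the limit of > 48000 nM in this assay, at which 3 of the 4 values shown sit.

Still open, from the compounds shown here alone, is whether an isopropyl group, a cyclopropyl ring or an amine on this same carbon would move the number further. Equally open, going by these compounds, is what a change to the methyl group on the ring would do.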